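The source may report more compounds than this note shows. Statements on the series, on what has been measured and on what is new or still open speak of the compounds shown alone.

Measured compounds in the series:
- compound 1 `Cc1ccc(S(=O)(=O)N2CCC(Br)=CC2CC(C)C)cc1`: 36000 nM
- compound 2 `Cc1ccc(S(=O)(=O)N2CCC(Br)=CC2C2CCCCC2)cc1`: 44000 nM

Both values come from a functional assay on A2780 cells (Homo sapiens) for antiproliferative activity, read by sulforhodamine B assay, with a stated time of 48 h; a higher number here means a weaker inhibitor of growth, a lower number a stronger inhibitor of growth. Compound 1 gives 36000 nM in this assay, and compound 2 gives 44000 nM, which is the highest of the two numbers; the nearest is compound 1, and the step of a 1.2-fold higher number from compound 1 to compound 2 (0.09 log units; within the scatter) is within the scatter, so the two stand together.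

The next compound is compound 3 `Cc1ccc(S(=O)(=O)N2CCC(Br)=CC2c2ccccc2)cc1`, not yet measured in this assay. It differs from compound 2 by phenyl in place of cyclohexyl on a saturated ring carbon. Within the data shown here, the only measured step that bears on this position is the one from compound 1 to compound 2, a 1.2-fold higher number from compound 1 to compound 2 (0.09 log units; within the scatter), which exchanged one non-aromatic group for another at the same saturated ring carbon without moving the number beyond the scatter. Among the measured compounds shown here, no measured step shows what an aromatic ring at this carbon does, so the expectation for compound 3 rests on that single step and is correspondingly wide. Compound 3 is expected to give about 40000 nM in this assay, with a range of 15000 nM to 100000 nM, which means an expected step of a 1.1-fold lower number from compound 2 to compound 3 (0.04 log units; within the scatter) not beyond the scatter.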

Compound 3, concentration for 50% growth inhibition: 49000 nM
Beside the measured number, compound 3's estimate is 1.2-fold (0.09 log units) below it; measured number inside the range.
By their numbers in this assay, from the lowest: compounds 1, 2 and 3 (each within the scatter of the next).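

At the saturated ring carbon next to the ring nitrogen, an aromatic ring now enters the series: in this assay, phenyl in place of cyclohexyl gives a 1.1-fold higher number from compound 2 to compound 3 (0.05 log units; within the scatter) and phenyl in place of isobutyl gives a 1.4-fold higher number from compound 1 to compound 3 (0.13 log units; within the scatter) on the same carbon. The earlier pair compared only non-aromatic groups, whereas these two steps show that exchanging either of them for an aromatic ring of the same heavy-atom count as cyclohexyl does not separate the numbers beyond the scatter, so isobutyl, cyclohexyl and phenyl all read alike at this position. No available evidence accounts for this sameness.

Still open is whether any group at this carbon can move the number beyond the scatter, since all three groups shown are carbon-only and carry no hydrogen-bond donors or acceptors, which leaves a group such as an amine, a carboxylic acid or a longer chain unaddressed. The bromo group and the sulfonyl-bearing part of the core are the same in compound 1, compound 2 and compound 3, so their contribution to the number also remains undefined.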